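Removing one methoxy from a trimethoxyphenyl pyrazole chalcone

The source may report more compounds than this note shows. Statements on the series, on what has been measured and on what is new or still open speak of the compounds shown alone.

Of the compounds shown here, three sharing one core have been tested in a functional assay on ACHN cells (Homo sapiens) for inhibition, read by sulforhodamine B assay, with a stated time of 48 h; on this read-out higher numbers stand for lower toxicity in this test and lower numbers for higher toxicity in this test. Compound 1 `COc1ccc(-c2cc(/C=C/C(=O)c3ccc(N)cc3)[nH]n2)cc1` gives 49200 nM. Compound 2 `COc1cc(-c2cc(/C=C/C(=O)c3ccc(N)cc3)[nH]n2)cc(OC)c1OC` gives 8400 nM, and compound 3 `COc1ccc(C(=O)/C=C/c2cc(-c3cc(OC)c(OC)c(OC)c3)n[nH]2)cc1` gives 6710 nM. On these numbers compound 2 stands second highest of the three: its value sits within the scatter of compound 3, while compound 1 gives a clearly higher number, meaning less toxicity in this test.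

The step now followed leads from compound 2 to compound 4 `COc1ccc(-c2cc(/C=C/C(=O)c3ccc(N)cc3)[nH]n2)cc1OC`. The change is hydrogen in place of methoxy on an aromatic carbon. For the measured compounds named here, the only single-point step measured so far, a 1.3-fold lower number from compound 2 to compound 3 (0.10 log units; within the scatter), concerns the amino-bearing ring rather than the methoxy-bearing ring, so it says little about this change. What bears on it is the gap between compound 1, which carries a single methoxy, and compound 2, which carries three: compound 1 gives the higher number. Compound 4, with two methoxy groups, lies between these two in structure, so an intermediate value is expected, with the number rising from compound 2 to compound 4 by a 2.4-fold higher number from compound 2 to compound 4 (0.38 log units; beyond the scatter). Compound 4 is therefore estimated at 20000 nM, with a likely range from 8000 nM to 50000 nM in this assay.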

Compound 4, concentration lethal to 50% of the cells: 6480 nM
Compound 4: middle estimate off by 3.1-fold (0.49 log units), on the high side; measured number below the stated range.
By their numbers in this assay, from the lowest: compounds 4, 3 and 2 (each within the scatter of the next); then compound 1.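

In this assay the change from methoxy to hydrogen on this aromatic carbon, ortho to a methoxy group, gives a 1.3-fold lower number from compound 2 to compound 4 (0.11 log units; within the scatter), so at this position the compounds shown do not separate methoxy from hydrogen. The other single change around compound 4 behaves quite differently: adding one methoxy to the ring of compound 1 gives a 7.6-fold lower number from compound 1 to compound 4 (0.88 log units; beyond the scatter), which places the wide gap between compound 1 and compound 2 at this one step and not at the step that adds the further methoxy. No measurement on hand accounts for the difference between these two methoxy changes.

The compounds shown leave open whether only methoxy and hydrogen are interchangeable on this carbon, or whether a hydroxyl group, a chlorine atom or a longer ethoxy chain there would also leave the number within the scatter. They also leave open whether the large step from compound 1 to compound 4 would hold if the amino group on the other ring were replaced by methoxy, as it is in compound 3.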